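A few compounds are considered here, and "the series" means these few. Any claim that something is new, unique, unknown or untested is made for them only; others in the source may bear on it.

Compound 2 `COC(=O)C1=C(C)NC(=S)NC1c1cccs1` gives the lower of the two measured numbers in an assay on membranes from HEK293 cells for displacement of a labelled ligand from adenosine receptor A2b (Homo sapiens), read by scintillation counting, with a stated time of 30 min, tested at 1 uM; a higher number here means more inhibition at the concentration tested (going by the name of the read-out), a lower number less inhibition: compound 2 gives 10%, whereas compound 1 `COC(=O)C1=C(C)NC(=S)NC1c1ccoc1` gives 48%. Among the measured compounds shown here, the one measured step, a number 38 percentage points lower from compound 1 to compound 2 (beyond the scatter), thus runs downward and lies beyond the scatter.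

Compound 3 `COC(=O)C1=C(C)NC(=S)NC1c1ccsc1` has not been measured. It differs from compound 2 in one place: thiophen-3-yl in place of thiophen-2-yl on a saturated ring carbon. The thiophen-3-yl group that enters shares its sulfur with the thiophen-2-yl group of compound 2, and it is joined to the saturated ring carbon in the same manner as the furan-3-yl group of compound 1. The measured step from compound 1 to compound 2 changed both the hetero atom and the point of attachment at once, so it bears on this step only in part, and its size cannot be split between the two changes.

Compound 3 is therefore expected to fall between the two measured values, with a rise of a number 18 percentage points higher from compound 2 to compound 3 (beyond the scatter) from compound 2. The estimate for compound 3 in this assay is 28%, in a range from 5% to 55%.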

Compound 3, a percentage reported as inhibition, at one concentration (the size of the read-out at that concentration, not a potency): 38%
Estimate against measurement, compound 3: 10 percentage points below, within the range that was stated.
By their numbers in this assay, from the lowest: compound 2; then compounds 3 and 1 (each within the scatter of the next).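

In this assay, moving the attachment point of the thiophene with the same atoms, thiophen-3-yl in place of thiophen-2-yl, gives a number 28 percentage points higher from compound 2 to compound 3 (beyond the scatter), so the attachment point alone matters at this saturated ring carbon. With the attachment point held constant, thiophen-3-yl in place of furan-3-yl gives a number 10 percentage points lower from compound 1 to compound 3 (within the scatter), so among these three compounds the earlier combined change from compound 1 to compound 2 follows the attachment point, and no effect of exchanging oxygen for sulfur can be told from the scatter. No measurement here explains why the attachment point counts in this way.

The compounds shown leave open whether furan-2-yl would follow thiophen-2-yl, which would test the attachment effect on a second ring, and whether phenyl at the same carbon would keep the values of compound 1 and compound 3. They also leave open how a carboxylic acid or an amide in place of the methoxycarbonyl group would act alongside either attachment.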